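The source may report more compounds than this note shows. Statements on the series, on what has been measured and on what is new or still open speak of the compounds shown alone.

Of the compounds shown here, three sharing one core have been measured in an ADME assay on microsomes from liver (Mus musculus) for pharmacokinetics; a lower number here means slower removal, a higher number faster removal of the compound. Compound 1 `Cc1ccc(S(=O)(=O)N[C@@H](CC(=O)NC(C)(C)C)C(=O)NCCNC(=O)c2ccccc2)cc1` gives 64 mL.min-1.g-1, compound 2 `COc1cccc(C(=O)NCCNC(=O)[C@H](CC(=O)NC(C)(C)C)NS(=O)(=O)c2ccc(C)cc2)c1` gives 142 mL.min-1.g-1, and compound 3 `Cc1ccc(S(=O)(=O)N[C@@H](CC(=O)NC(C)(C)C)C(=O)NCCNC(=O)c2ccccc2F)cc1` gives 141 mL.min-1.g-1. Compound 3 therefore stands level with compound 2 at the upper end of these numbers, with a 1.0-fold lower number from compound 2 to compound 3 (0.00 log units; within the scatter).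

Compound 4 `Cc1ccc(S(=O)(=O)N[C@@H](CC(=O)NC(C)(C)C)C(=O)NCCNC(=O)c2ccc(F)cc2)cc1` keeps the same atoms but relocates the fluorine: 4-fluorophenyl in place of 2-fluorophenyl on a carbonyl carbon. In short, 4-fluorophenyl comes in place of 2-fluorophenyl on a carbonyl carbon. For the measured compounds named here, no measured step makes this exact change. The closest evidence comes from two modest steps on the aromatic ring of compound 1: a 2.2-fold higher number from compound 1 to compound 3 (0.34 log units; beyond the scatter) for fluoro in place of hydrogen, and a 2.2-fold higher number from compound 1 to compound 2 (0.35 log units; beyond the scatter) for methoxy in place of hydrogen. Both end at matching numbers despite carrying different groups, so moving the fluorine is not expected to shift this assay beyond the scatter. The expected change is a 1.2-fold lower number from compound 3 to compound 4 (0.09 log units; within the scatter). For compound 4 the estimated number is 115 mL.min-1.g-1, with an expected range from 60 mL.min-1.g-1 to 210 mL.min-1.g-1.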

Compound 4, intrinsic clearance in microsomes: 49 mL.min-1.g-1
The estimate for compound 4 lay 2.3-fold (0.37 log units) above the measured number, and the stated range ends above it.
By their numbers in this assay, from the lowest: compounds 4 and 1 (each within the scatter of the next); then compounds 3 and 2 (each within the scatter of the next).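

The placement of the fluorine matters in this assay: the same atoms, joined differently, give a 2.9-fold lower number from compound 3 to compound 4 (0.46 log units; beyond the scatter), so 2-fluorophenyl and 4-fluorophenyl are not interchangeable on this carbonyl carbon. With 4-fluorophenyl, the number stays level with that of the plain phenyl compound, a 1.3-fold lower number from compound 1 to compound 4 (0.12 log units; within the scatter), so placing a fluorine on this ring does not by itself give a higher number. The 3-methoxyphenyl compound stands clearly apart, a 2.9-fold lower number from compound 2 to compound 4 (0.46 log units; beyond the scatter), which shows that compound 2 and compound 3 share a high number that compound 4 does not reach. Nothing measured here explains why the two fluorine placements differ.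

The compounds shown leave open whether placement matters in the same way for methoxy. They also leave open how a chlorine or an amine on this ring would read in this assay.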